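One Double Bond, Drawn Two Ways

The compounds below may be only part of what the source reports. "The series", "measured", "known", "first", "only" and "open" are said of these compounds alone.

Among the compounds with values here, in a functional assay on U-87MG ATCC cells (Homo sapiens) for cytotoxicity, read by MTT assay, with a stated time of 48 h (on this read-out higher numbers stand for weaker inhibition and lower numbers for stronger inhibition), compound 1 (`C/C(=N\NC(=S)Nc1ccccc1F)c1ccccn1`) gives 5 nM and compound 2 (`C/C(=N/NC(=S)Nc1ccccc1[N+](=O)[O-])c1ccccn1`) gives 4.3 nM, so compound 2 stands within the usual scatter of the only other measured value. Compound 3 (`C/C(=N\NC(=S)Nc1ccccc1[N+](=O)[O-])c1ccccn1`) has not yet been measured. The change is this: the two compounds have the same atoms and bonds and differ only in configuration as drawn: 1 of 1 stereo elements differ; a double bond is drawn Z in compound 2 and E in compound 3. Within the data shown here, no measured pair shows a change of this kind, so the expectation is loose. No shift beyond the scatter is expected in this assay, only an estimated 1.2-fold higher number from compound 2 to compound 3 (0.07 log units; within the scatter). For compound 3 the expected value is 5 nM, with an estimated range of 2 nM to 12 nM.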

Compound 3, half-maximal inhibitory concentration: 4.3 nM
Compound 3: the middle estimate sits 1.2-fold (0.07 log units) above what was measured; the measured number falls inside the stated range.
By their numbers in this assay, from the lowest: compounds 2, 3 and 1 (each within the scatter of the next).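

In this assay drawing the double bond the other way gives no change at the digits printed from compound 2 to compound 3 (within the scatter). This comparison tests the double bond alone, because nothing else changes: the fact that compounds 2 and 3 differ only in the configuration as drawn. Nitro in place of fluoro on an aromatic carbon, now seen with the double bond drawn alike, gives a 1.2-fold lower number from compound 1 to compound 3 (0.07 log units; within the scatter), so neither single change moves the number beyond the scatter. Still open, going by these compounds, is whether an amine or a carboxylic acid on that aromatic carbon would shift the value. Also open, on these data alone, is whether the drawn configuration matters when fluoro replaces nitro.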